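Notes on the amide series: ring amine to propoxy

The compounds below may be only part of what the source reports. "The series", "measured", "known", "first", "only" and "open" are said of these compounds alone.

Measured in an assay on CHO cells for antagonist activity at transient receptor potential cation channel subfamily V member 1 (Homo sapiens), read by FLIPR; a lower number here means a stronger inhibitor, a higher number a weaker inhibitor:
compound 1 `CC(C(=O)NCc1ccc(C(F)(F)F)cc1N1CCCCCCC1)c1ccc(NS(C)(=O)=O)c(F)c1`, 2.8 nM
compound 2 `Cc1cccc(N2CCN(c3cc(C(F)(F)F)ccc3CNC(=O)C(C)c3ccc(NS(C)(=O)=O)c(F)c3)CC2)c1`, 1.8 nM
compound 3 `COc1ccc(N2CCN(c3cc(C(F)(F)F)ccc3CNC(=O)C(C)c3ccc(NS(C)(=O)=O)c(F)c3)CC2)cc1`, 1.6 nM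

Compound 1 gives the highest of the three numbers, yet its gaps to compound 2 and to compound 3 are both within the scatter, so no order among the three is claimed. Going by the values given here, the single measured step, a 1.1-fold lower number from compound 2 to compound 3 (0.05 log units; within the scatter), concerns the aryl on the amine nitrogen in a ring and does not touch the position changed next. Compound 4 `CCCOc1cc(C(F)(F)F)ccc1CNC(=O)C(C)c1ccc(NS(C)(=O)=O)c(F)c1` differs from compound 1 by a group of 4 heavy atoms (3 carbon, 1 oxygen; no ring) in place of a group of 8 heavy atoms (7 carbon, 1 nitrogen; one eight-membered non-aromatic ring with 1 hetero atom), on an aromatic carbon. Among the compounds with values here, no measured step bears on that exchange, so the expectation is uncertain; a step toward a weaker number is expected, a 3.6-fold higher number from compound 1 to compound 4 (0.55 log units; beyond the scatter). Compound 4 is estimated at 10 nM, with a range of 2.5 nM to 40 nM in this assay.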

Compound 4, inhibition constant: 2 nM
Estimate against measurement, compound 4: 5.0-fold (0.70 log units) above; measured number below the stated range.
By their numbers in this assay, from the lowest: compounds 3, 2, 4 and 1 (each within the scatter of the next).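

Propoxy in place of the eight-membered non-aromatic ring, on the aromatic carbon meta to a trifluoromethyl group, gives a 1.4-fold lower number from compound 1 to compound 4 (0.15 log units; within the scatter) in this assay. Compounds 1, 2 and 3 all carry a ring amine at this carbon, and compound 4 shows that a group with no ring, joined through oxygen, stays level with compound 1 here. Nothing measured on these compounds accounts for this result.

On these data alone, whether methoxy, a longer chain such as hexyloxy, or an open-chain amine such as diethylamino would hold this level at the same carbon remains open.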